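This account rests on a few compounds, and the source may have more. Where it says the series, first, only, none or still open, it means among the compounds named here.

The series shares the core of compound 1 `C[C@H](NC(=O)[C@H](C)[C@H]1CC[C@@H](c2ccnc3ccc(F)cc32)CC1)c1ccc(Cl)cc1`. In an assay on tissue (M109 cells) for inhibition of Indoleamine 2,3-dioxygenase 1 (Mus musculus), with stated times of 2 h and 18 h (on this read-out higher numbers stand for weaker inhibition and lower numbers for stronger inhibition), compound 1 gives 870 nM. Compound 2 `C[C@@H](C(=O)NC1CCCCC1)[C@H]1CC[C@@H](c2ccnc3ccc(F)cc32)CC1` carries a cyclohexyl in place of the 1-(4-chlorophenyl)ethyl on the amide nitrogen; in this assay compound 2 gives 287 nM, and the step is a 3.0-fold lower number from compound 1 to compound 2 (0.48 log units; beyond the scatter). Compound 3 `C[C@@H](NS(=O)(=O)c1ccc(Cl)cc1)[C@H]1CC[C@@H](c2ccnc3ccc(F)cc32)CC1` carries a (4-chlorophenyl)sulfonyl on the amine nitrogen. In this assay compound 3 reaches only a limit, > 1000 nM. This is the limit of > 1000 nM in this assay, at which 1 of the 3 values shown sits, so for compound 3 no number is known, only that it sits at that limit.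

Compound 4 `C[C@@H](NC(=O)c1ccccc1Cl)[C@H]1CC[C@@H](c2ccnc3ccc(F)cc32)CC1` differs from compound 3 by (2-chlorophenyl)carbonyl in place of (4-chlorophenyl)sulfonyl on an amine nitrogen. Within the data shown here, no measured step exchanges a sulfonyl for a carbonyl on this nitrogen. Among the measured compounds shown here, the only measured step, a 3.0-fold lower number from compound 1 to compound 2 (0.48 log units; beyond the scatter), varies the group on an amide nitrogen and is modest; it does not bear directly on the present change. Compound 1 at 870 nM and compound 2 at 287 nM, both carbonyl-linked, give numbers in this assay. On that ground, for compound 4 a step toward lower numbers in this assay is expected, an at least 1.6-fold lower number from compound 3 to compound 4 (0.22 log units; that floor lies within the scatter), though with wide uncertainty. Compound 4 is estimated at 600 nM, with a range from 150 nM to 2500 nM.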

Compound 4, half-maximal inhibitory concentration: 215 nM
Compound 4: middle estimate off by 2.8-fold (0.45 log units), on the high side, within the range that was stated.
By their numbers in this assay, from the lowest: compounds 4 and 2 (each within the scatter of the next); then compound 1. At a limit, above all of these: compound 3.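

Among these compounds, on this amine nitrogen, (2-chlorophenyl)carbonyl in place of (4-chlorophenyl)sulfonyl gives an at least 4.6-fold lower number from compound 3 to compound 4 (0.66 log units; beyond the scatter) in this assay, which is the only measured step at this position and lies beyond the scatter. The size of that step is a floor and not a measured difference, since the value for compound 3 is only a limit of the assay: the limit of > 1000 nM in this assay, at which 1 of the 4 values shown sits. The exchange also alters two things at once, the linking group (sulfonyl to carbonyl) and the placement of the chlorine on the aromatic ring, so the step belongs to the pair of changes taken together and cannot be assigned to either one.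

The compounds shown leave open which of the two changes carries the step, a question that (4-chlorophenyl)carbonyl or (2-chlorophenyl)sulfonyl on the same nitrogen would separate. Also open, on these data alone, is how this nitrogen tolerates groups without chlorine, such as an unsubstituted phenylcarbonyl, a cyclohexylcarbonyl, or a phenylcarbonyl bearing a carboxylic acid or an amine.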